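Changing One Aryl Substituent While Cytotoxicity Sits at a Limit

The compounds below may be only part of what the source reports. "The series", "measured", "known", "first", "only" and "open" are said of these compounds alone.

Compound 3 `CCOC(=O)CCCCCOc1cccc(CN(C(=O)c2ccc(-c3cccc(OC(C)C)c3)cc2)C(C)C)c1` is the starting point here. In an ADME assay on Raji cells (Homo sapiens) for cytotoxicity, read by CellTiter-Glo and resazurin assay, with a stated time of 72 h (on this read-out higher numbers stand for an effect only at larger amounts of compound and lower numbers for an effect already at smaller amounts), compound 3 gives > 26000 nM, which is a limit of the assay rather than a number. Two neighbours have been measured alongside it. Compound 1 `CCOC(=O)CCCCCOc1cccc(CN(C(=O)c2ccc(-c3cnc(OC)nc3OC)cc2)C(C)C)c1` gives > 26000 nM in this assay, again a limit. Compound 2 `CCOC(=O)CCCCCOc1cccc(CN(C(=O)c2ccc(-c3cccc(C(C)=O)c3)cc2)C(C)C)c1` gives > 26000 nM in this assay, likewise a limit. All three values therefore sit at the same place, (the limit of > 26000 nM in this assay, at which 3 of the 3 values shown sit), and the steps between them, a step that the two limits leave unreadable from compound 1 to compound 2, a step that the two limits leave unreadable from compound 1 to compound 3 and a step that the two limits leave unreadable from compound 2 to compound 3, cannot be read in size or direction.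

The next compound, compound 4 `CCOC(=O)CCCCCOc1cccc(CN(C(=O)c2ccc(-c3cc(OC)cc(OC)c3)cc2)C(C)C)c1`, differs from compound 3 in one place: 3,5-dimethoxyphenyl in place of 3-isopropoxyphenyl on an aromatic carbon

Among the compounds with values here, no measured step can guide this change, since every step among the measured compounds stays hidden by the limit. Given that compound 3 sits at the limit of > 26000 nM in this assay, at which 3 of the 3 values shown sit, compound 4 is expected to stay there as well, giving an estimated 30000 nM in this assay, with a likely range from 13000 nM to 100000 nM. The estimated step is a step that the limit leaves unreadable from compound 3 to compound 4, meaning no change beyond the scatter is expected.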

Compound 4, half-maximal effective concentration: > 26000 nM
Compound 4 ended at the assay's limit (the forecaster's own chance of this, stated with the estimate: 85%); the middle value lies beyond the limit too.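

In this assay compound 4 gives > 26000 nM and that value is a limit, so its steps to compound 1, compound 2 and compound 3 cannot be read: the limit of > 26000 nM in this assay, at which 4 of the 4 values shown sit.

The compounds shown leave open how far each lies past this limit, and whether changing this aryl group alters the read-out at all.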